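A few compounds are considered here, and "the series" means these few. Any claim that something is new, unique, unknown or untested is made for them only; others in the source may bear on it.

Measured compounds:
- compound 1, `C=C(Br)C(=O)Nc1ccc(/C=C2\SC(=O)N(Cc3ccc(F)cc3)C2=O)cc1`: 2200 nM
- compound 2, `C=C(Br)C(=O)Nc1ccc(/C=C2\SC(=O)N(Cc3ccc(C(F)(F)F)cc3)C2=O)cc1`: 12000 nM
- compound 3, `C=C(Br)C(=O)Nc1ccc(/C=C2\SC(=O)N(C)C2=O)cc1`: 190 nM

All three values come from a functional assay on L1210 cells (Mus musculus) for cytotoxicity, read by cell counting, with a stated time of 2 days; on this read-out higher numbers stand for weaker inhibition and lower numbers for stronger inhibition. Compound 3 holds the lowest number of the three; its nearest neighbour is compound 1, at a 12-fold lower number from compound 1 to compound 3 (1.06 log units; beyond the scatter) read in reverse, and its furthest is compound 2, at a 63-fold lower number from compound 2 to compound 3 (1.80 log units; beyond the scatter) read in reverse. Compound 1 and compound 2 differ from each other by a 5.5-fold higher number from compound 1 to compound 2 (0.74 log units; beyond the scatter).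

Compound 4, `C=C(Br)C(=O)Nc1ccc(/C=C2\SC(=O)N(Cc3ccc(Cl)cc3)C2=O)cc1`, is the next member to be measured in this assay. Relative to compound 3 the change is 4-chlorophenyl in place of hydrogen on a saturated chain carbon bound to an amide-type nitrogen in a ring.

The two steps that bear on this are the same kind of change run the other way: removing the 4-fluorophenyl gave a 12-fold lower number from compound 1 to compound 3 (1.06 log units; beyond the scatter) and removing the 4-(trifluoromethyl)phenyl gave a 63-fold lower number from compound 2 to compound 3 (1.80 log units; beyond the scatter). Both are large and both point the same way, so adding a 4-chlorophenyl at this place is expected to raise the number in this assay by a large step, most likely somewhere between the two reversed steps. The expected step is an 18-fold higher number from compound 3 to compound 4 (1.27 log units; beyond the scatter). Compound 4 is therefore estimated at 3500 nM, with a range of 1200 nM to 10000 nM.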

Compound 4, half-maximal inhibitory concentration: 3400 nM
Beside the measured number, compound 4's estimate is 1.0-fold (0.01 log units) above it; the range from low to high includes it.
By their numbers in this assay, from the lowest: compound 3; then compounds 1 and 4 (each within the scatter of the next); then compound 2.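

In this assay, 4-chlorophenyl in place of hydrogen on a saturated chain carbon bound to an amide-type nitrogen in a ring gives (an 18-fold higher number from compound 3 to compound 4 (1.25 log units; beyond the scatter)), so a third aryl group on this carbon leaves the number well above that of compound 3, and no compound shown goes against this. On the aromatic carbon, chloro in place of fluoro gives (a 1.5-fold higher number from compound 1 to compound 4 (0.19 log units; within the scatter)), which does not separate these two halogens, whereas chloro in place of trifluoromethyl gives (a 3.5-fold lower number from compound 2 to compound 4 (0.55 log units; beyond the scatter)). The ring substituent therefore matters in this series only for the trifluoromethyl member, compound 2.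

Nothing available explains either the large step or the trifluoromethyl difference. On these data alone, what an amine, a carboxylic acid or a longer chain on that saturated chain carbon would give remains open.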